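The source may hold more compounds than are shown below. What is called first, only, known or untested is meant among the compounds shown, and "the series" means these compounds.

Values in an ADME assay on WI-38 cells (Homo sapiens) for cytotoxicity, read by MTT assay, with a stated time of 72 h; on this read-out higher numbers stand for weaker inhibition and lower numbers for stronger inhibition:

- Compound 1 `CC(=O)c1ccc(-c2cccc(NC(=O)CCc3ccc4c(c3)B(O)OC4)c2)cc1` gives > 100000 nM, which is a limit.
- Compound 2 `CC(=O)c1ccc(-c2cccc(NC(=O)CCc3cccc4c3COB4O)c2)cc1` gives > 100000 nM, which is a limit.
- Compound 3 `COc1cccc(-c2cccc(NC(=O)CCc3cccc4c3C(O)OC4)c2)c1` gives 93000 nM, a measured number.

For the measured compounds named here, compound 3 holds the only number, so its place relative to the other two cannot be read. The next compound is compound 4 `CC(=O)c1ccc(-c2cccc(NC(=O)CCc3cccc4c3C(O)OC4)c2)cc1`, which has 4-acetylphenyl in place of 3-methoxyphenyl on an aromatic carbon, meta to a large group, and keeps the core of compound 3: 4-acetylphenyl in place of 3-methoxyphenyl on an aromatic carbon.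

Going by the values given here, no measured step covers this exchange. Among the compounds with values here, the only step available is a step that the two limits leave unreadable from compound 1 to compound 2, which gives no size and leaves the 4-acetylphenyl group unchanged. Compound 1 and compound 2 do carry the 4-acetylphenyl group that enters in compound 4, but on cores different from that of compound 3, and they stand at the limit of > 100000 nM in this assay, at which 2 of the 3 values shown sit. That offers only weak support for a shift towards weaker inhibition, and no step beyond the usual scatter is expected. The expected change is a 1.1-fold higher number from compound 3 to compound 4 (0.03 log units; within the scatter), and the assay may well report only a limit. The estimated value for compound 4 is 100000 nM, with an expected range from 55000 nM to 180000 nM.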

Compound 4, half-maximal inhibitory concentration: > 100000 nM
Compound 4 ended at the assay's limit; the forecaster's own chance of this, stated with the estimate: 55%; the middle value lies on the limit itself.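

In this assay compound 4 gives > 100000 nM, which is a limit and not a number. For the compounds shown here, on the core of compound 3, 4-acetylphenyl in place of 3-methoxyphenyl on an aromatic carbon, meta to a large group, gives an at least 1.0-fold higher number from compound 3 to compound 4 (0.03 log units; that floor lies within the scatter), so this is the first exchange at this position on a single core, but its size is bounded from one side only and may be no more than scatter. The steps from compound 1 and from compound 2 to compound 4 cannot be read, and the three cores carrying 4-acetylphenyl therefore stay unranked, with the series now largely resting on: the limit of > 100000 nM in this assay, at which 3 of the 4 values shown sit.

Still open, from the compounds shown here alone, is how far the number of compound 4 lies from that of compound 3, and whether the core matters at all once 4-acetylphenyl is present. Also open, going by these compounds, is whether a carboxylic acid or an amine in place of the acetyl group on that ring would give a measured number in this assay rather than a limit.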